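Aryl swap on the shared core: acid dissociation notes

This account rests on a few compounds, and the source may have more. Where it says the series, first, only, none or still open, it means among the compounds named here.

Compound 1 `CC(C)Cc1ccc2c(NCCCNCc3ccco3)ccnc2c1` — 9.47
Compound 2 `COc1ccc(F)cc1CNCCCNc1ccnc2cc(Oc3ccc(F)cc3)ccc12` — 9.28
Compound 3 `Fc1ccc(Oc2ccc3c(NCCCNCc4ccco4)ccnc3c2)cc1` — 9.28

In a physicochemical assay for acid dissociation, compound 3 stands level with compound 2 at the digits shown, the two together forming the lowest of the three numbers; the gap to compound 1 lies within the scatter. Compound 4 `COc1ccc(-c2ccc3c(NCCCNCc4ccco4)ccnc3c2)cc1` differs from compound 3 by 4-methoxyphenyl in place of 4-fluorophenoxy on an aromatic carbon. The step that bears on this change is a number 0.19 log units lower from compound 1 to compound 3 (within the scatter), the earlier swap on an aromatic carbon of the shared core; the other step, no change at the digits printed from compound 2 to compound 3 (within the scatter), changes a different part of the molecule. Both fall within the scatter, so no step beyond the scatter is expected in this assay for compound 4. Compound 4 is therefore estimated at 9.3, range 9 to 9.6. The expected step is a number 0.02 log units higher from compound 3 to compound 4 (within the scatter).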

Compound 4, acid dissociation constant: 9.47
The estimate for compound 4 lay 0.17 log units below the measured number, and the stated range covers the measured number.
By their numbers in this assay, from the lowest: compounds 2, 3, 1 and 4 (each within the scatter of the next).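

In this assay, 4-methoxyphenyl in place of 4-fluorophenoxy gives a number 0.19 log units higher from compound 3 to compound 4 (within the scatter) and 4-methoxyphenyl in place of isobutyl gives no change at the digits printed from compound 1 to compound 4 (within the scatter) on the same aromatic carbon. With furan-2-yl held on the chain, this read-out therefore does not separate these three groups at this position. No supporting evidence bears on these numbers.

Open, as far as these compounds go, is whether an amine or a carboxylic acid on this aromatic carbon would give a step beyond the scatter. Also open, from the compounds shown here alone, is whether 4-methoxyphenyl reads the same with 5-fluoro-2-methoxyphenyl on the chain.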